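From oxazole to thiazole on compound 1

The compounds below may be only part of what the source reports. "The series", "measured", "known", "first", "only" and "open" are said of these compounds alone.

In a physicochemical assay for solubility, measured as kinetic solubility, at pH 2 (a lower number here means a less soluble compound, a higher number a more soluble compound), compound 1 `CC(C)c1coc(-c2cccc(CNc3ccc4[nH]nc(C(=O)O)c4c3)c2O)n1` gives 4000 nM, second highest of the three measured values. Compound 3 `CN(C)c1noc(-c2cccc(CNc3cnc4nn[nH]c4c3)c2O)n1` gives 530 nM, and compound 2 `CN(C)c1noc(-c2cccc(CNc3ccc4[nH]nc(C(=O)O)c4c3)c2)n1` gives 308000 nM. Within the data shown here, the gaps from compound 1 to both lie beyond the scatter, but no measured pair differs in one place only, so the size of a single swap remains uncalibrated. Compound 4 `Cc1nc(-c2cccc(CNc3ccc4[nH]nc(C(=O)O)c4c3)c2O)sc1C` keeps the core of compound 1 and changes one group: 4,5-dimethyl-1,3-thiazol-2-yl in place of 4-isopropyl-1,3-oxazol-2-yl on an aromatic carbon. The new group sits on an aromatic carbon, ortho to a hydroxy group. Only a small downward move in this assay is expected, possibly none beyond the scatter. The estimated change is a 1.6-fold lower number from compound 1 to compound 4 (0.20 log units; within the scatter). For compound 4 the expected value is 2500 nM, with an estimated range of 600 nM to 8000 nM.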

Compound 4, solubility: 20000 nM
Beside the measured number, compound 4's estimate is 8.0-fold (0.90 log units) below it; the measured number lies above the stated range.
By their numbers in this assay, from the lowest: compound 3; then compound 1; then compound 4; then compound 2.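

In this assay, among these compounds, the first single-place step reads a 5.0-fold higher number from compound 1 to compound 4 (0.70 log units; beyond the scatter) and so gives a size for a swap at this position, which the earlier compounds could not. Exchanging the 4-isopropyl-1,3-oxazol-2-yl group for a 4,5-dimethyl-1,3-thiazol-2-yl group, ortho to a hydroxy group, raises the number beyond the scatter, though this rests on one pair only. No available evidence bears on what lies behind this step.

The compounds shown do not separate the ring sulfur from the changed alkyl substituents as the source of the step. Going by these compounds, how a primary amide or a morpholine on this aromatic carbon would read in this assay also stays open.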